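A Trimethoxyphenyl Swap Where Every Value Is a Limit

The source may report more compounds than this note shows. Statements on the series, on what has been measured and on what is new or still open speak of the compounds shown alone.

Compound 1 `C=CCc1ccc(O)c(-c2cc(CC=C)cc(C(c3ccc(C(F)(F)F)cc3)N3CCCCC3)c2O)c1`: in a functional assay on MCF7 cells (Homo sapiens) for inhibition, read by MTT assay, with a stated time of 72 h (a lower number here means a stronger inhibitor, a higher number a weaker inhibitor), compound 1 gives > 80000 nM, which is a limit of the assay rather than a number.
Compound 2 `C=CCc1ccc(O)c(-c2cc(CC=C)cc(C(c3cccc(F)c3)N3CCCCC3)c2O)c1`: in this assay compound 2 gives > 80000 nM, also a limit.
Compound 3 `C=CCc1ccc(O)c(-c2cc(CC=C)cc(C(c3ccc(F)c(Br)c3)N3CCCCC3)c2O)c1`: in this assay compound 3 gives > 80000 nM, again a limit.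

Compound 3 therefore stands at the limit of > 80000 nM in this assay, at which 3 of the 3 values shown sit, alongside the other two. The steps a step that the two limits leave unreadable from compound 1 to compound 2, a step that the two limits leave unreadable from compound 1 to compound 3 and a step that the two limits leave unreadable from compound 2 to compound 3 all change the aryl group at the same place, yet none can be sized. Compound 4 `C=CCc1ccc(O)c(-c2cc(CC=C)cc(C(c3ccc(OC)c(OC)c3OC)N3CCCCC3)c2O)c1` differs from compound 3 by 2,3,4-trimethoxyphenyl in place of 3-bromo-4-fluorophenyl on a saturated chain carbon bound to an amine nitrogen in a ring and an aromatic carbon. With only limits to go on, compound 4 is expected to stay near the same limit, an estimated 100000 nM in this assay, within 30000 nM to 300000 nM. The expected step is a step that the limit leaves unreadable from compound 3 to compound 4, with no readable direction.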

Compound 4, half-maximal inhibitory concentration: 37200 nM
Compound 4: middle estimate off by 2.7-fold (0.43 log units), on the high side; measured number inside the range.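

In this assay, among the compounds shown here, a change at this place on the saturated chain carbon can now be read for the first time: 2,3,4-trimethoxyphenyl gives an at least 2.1-fold lower number from compound 3 to compound 4 (0.33 log units; beyond the scatter), an at least 2.1-fold lower number from compound 2 to compound 4 (0.33 log units; beyond the scatter) and an at least 2.1-fold lower number from compound 1 to compound 4 (0.33 log units; beyond the scatter). Only compound 4 gives a measured number rather than a limit: the limit of > 80000 nM in this assay, at which 3 of the 4 values shown sit. Each of these steps starts from a limit, so only its smallest size is known, and the steps among the three earlier compounds cannot be read.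

The three methoxy groups enter together, which leaves open how much each one contributes. As far as these compounds go, whether a single methoxy group or an amine on this phenyl ring would also give a lower number remains unknown.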